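The source may report more compounds than this note shows. Statements on the series, on what has been measured and on what is new or still open speak of the compounds shown alone.

In an ADME assay on HepG2 cells (Homo sapiens) for cytotoxicity (on this read-out higher numbers stand for an effect only at larger amounts of compound and lower numbers for an effect already at smaller amounts), compound 1 (`Cc1ccc(S(=O)(=O)N[C@@H](CC(=O)NC(C)(C)C)C(=O)NCCNC(=O)c2cccc(O)c2)cc1`) gives > 11000 nM as a limit of the assay. Compound 2 (`Cc1ccc(S(=O)(=O)N[C@@H](CC(=O)NC(C)(C)C)C(=O)NCCNC(=O)c2cccc(C#N)c2)cc1`) gives > 11000 nM as a limit too. Compound 3 (`Cc1ccc(S(=O)(=O)N[C@@H](CC(=O)NC(C)(C)C)C(=O)NCCNC(=O)NCc2ccccc2)cc1`) stands at > 11000 nM which is again a limit and not a number. Among the compounds with values here, the series so far lies at the limit of > 11000 nM in this assay, at which 3 of the 3 values shown sit, and compound 3 shares that position.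

Compound 4 (`Cc1ccc(S(=O)(=O)N[C@@H](CC(=O)NC(C)(C)C)C(=O)NCCNC(=O)c2ccccc2O)cc1`) differs from compound 3 by 2-hydroxyphenyl in place of benzylamino on a carbonyl carbon with 2-hydroxyphenyl in place of benzylamino on a carbonyl carbon. Since a step that the two limits leave unreadable from compound 1 to compound 3 and a step that the two limits leave unreadable from compound 2 to compound 3 at a carbonyl carbon and a step that the two limits leave unreadable from compound 1 to compound 2 on an aromatic carbon offer no size, no step beyond the scatter is expected in this assay for this change. The expected change is a step that the limit leaves unreadable from compound 3 to compound 4 with no direction favoured. For compound 4 the estimate is 15000 nM with an expected range of 11000 nM to 30000 nM and a report as a limit once more is the likeliest outcome.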

Compound 4, half-maximal effective concentration: > 11000 nM
Compound 4 ended at the assay's limit (the forecaster's own chance of this, stated with the estimate: 85%); the middle value lies beyond the limit too.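

In this assay compound 4 gives > 11000 nM, which is a limit and not a number, so its steps from compound 1, compound 2 and compound 3 cannot be read. The compounds shown leave open whether any structural change in the series would yield a measurable value, as all remain at one position: the limit of > 11000 nM in this assay, at which 4 of the 4 values shown sit.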